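A few compounds are considered here, and "the series" means these few. Any claim that something is new, unique, unknown or untested is made for them only; others in the source may bear on it.

Measured compounds:
Compound 1 `COCCCOc1cc(C)c(-c2cccc(COc3ccc(OCC(=O)O)c(F)c3)c2)c(C)c1` – in a physicochemical assay for lipophilicity, using the shake flask method, in phosphate buffer, measured as octanol-water partition, with a stated time of 24 h, at pH 7.4, tested at 100 uM (on this read-out lower numbers stand for lower lipophilicity and higher numbers for higher lipophilicity), compound 1 gives "not determined" (no result reported).
Compound 2 `Cc1cc(O)cc(C)c1-c1cccc(COc2ccc(OCC(=O)O)c(F)c2)c1` – in this assay compound 2 gives 2.37.

For the measured compounds named here, compound 2 is the only one of the two with a number, so it stands alone: there is no second value to place it above or below, and no step between measured compounds can be read from the pair.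

Compound 3 `Cc1cc(OCCCS(C)(=O)=O)cc(C)c1-c1cccc(COc2ccc(OCC(=O)O)c(F)c2)c1` has not yet been tested. Its structure follows from compound 2 by one change: 3-(methylsulfonyl)propyl in place of hydrogen on an oxygen on an aromatic ring. Cut one bond further out, the change reads hydroxy to 3-(methylsulfonyl)propoxy, and the entering group carries no hydrogen-bond donors and no charge.

Going by the values given here, with no measured step to lean on, the expectation rests on the change alone. The step from compound 2 to compound 3 is expected to be small, most likely within the usual scatter or just above it in the direction of higher lipophilicity, at a number 0.18 log units higher from compound 2 to compound 3 (within the scatter). Compound 3 is therefore expected to give about 2.55, with a likely range from 2.05 to 3.05.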

Compound 3, distribution coefficient: 1.81
Beside the measured number, compound 3's estimate is 0.74 log units above it; the whole stated range lies above it.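

For the compounds shown here, on the oxygen on an aromatic ring, the earlier compounds offered a single number and no step, but now the position has a measured response: in this assay, replacing the hydroxy with 3-(methylsulfonyl)propoxy gives a number 0.56 log units lower from compound 2 to compound 3 (beyond the scatter) and places the change beyond the usual scatter. For this one pair, a group far larger than the hydrogen it replaces goes with a lower number, so added size at this position does not by itself mean a higher reading. Nothing shown here explains why the number moves in this direction.

Steps involving compound 1, which carries a different chain on the same oxygen, cannot be read, so this single step cannot yet be compared with any other group at this position. On these data alone, it remains open whether a plain butyl chain, a longer chain ending in the same methylsulfonyl group, or a propyl chain ending in an amine would lower the number as well, or whether the result belongs to 3-(methylsulfonyl)propyl alone.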